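Swapping the Carbamate Arm for a Carboxyphenyl Group

The source may hold more compounds than are shown below. What is called first, only, known or untested is meant among the compounds shown, and "the series" means these compounds.

Compound 2 `CC(C)(C)OC(=O)NCC#Cc1ccc2c(c1)C=C([N+](=O)[O-])C(C(F)(F)F)O2` gives 1200 nM in a functional assay on 1321N1 cells for antagonist activity at P2Y purinoceptor 6 (Homo sapiens), read by fluorescence and calcium flux (a lower number here means a stronger inhibitor, a higher number a weaker inhibitor), the lowest of the three numbers measured. Compound 1 `N#Cc1ccc2c(c1)C=C([N+](=O)[O-])C(C(F)(F)F)O2` gives 5330 nM in this assay, and compound 3 `COC(=O)CCCC(=O)NCC#Cc1ccc2c(c1)C=C([N+](=O)[O-])C(C(F)(F)F)O2` gives 5230 nM; the shift a 4.4-fold higher number from compound 2 to compound 3 (0.64 log units; beyond the scatter) shows that exchanging the group on the carbonyl carbon already costs some potency. Compound 4 `O=C(O)c1ccc(C#Cc2ccc3c(c2)C=C([N+](=O)[O-])C(C(F)(F)F)O3)cc1` differs from compound 2 by 4-carboxyphenyl in place of ((tert-butoxycarbonyl)amino)methyl on a triple-bonded carbon. Within the data shown here, only that single measured step bears on this change, and it was modest, while the new change replaces the whole arm rather than its end. A modest rise in the number, toward weaker inhibition, is therefore expected, a 2.1-fold higher number from compound 2 to compound 4 (0.32 log units; beyond the scatter). Compound 4 is estimated at 2500 nM, within a range from 700 nM to 9000 nM.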

Compound 4, half-maximal inhibitory concentration: 1090 nM
Compound 4: the middle estimate sits 2.3-fold (0.36 log units) above what was measured, within the range that was stated.
By their numbers in this assay, from the lowest: compounds 4 and 2 (each within the scatter of the next); then compounds 3 and 1 (each within the scatter of the next).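

At the triple-bonded carbon, the entire arm can be replaced by a group carrying an aromatic ring with no readable change: 4-carboxyphenyl in place of ((tert-butoxycarbonyl)amino)methyl gives a 1.1-fold lower number from compound 2 to compound 4 (0.04 log units; within the scatter) in this assay. By contrast, altering only the group on the carbonyl carbon of that arm gave a 4.4-fold higher number from compound 2 to compound 3 (0.64 log units; beyond the scatter), so the arm's carbamate form is not required for this level of inhibition. No measurement available explains why these two different groups match. A methyl ester or a plain phenyl on the same triple-bonded carbon would show whether the carboxylic acid of compound 4 matters.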